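The source may report more compounds than this note shows. Statements on the series, on what has been measured and on what is new or still open speak of the compounds shown alone.

Within the data shown here, compound 1, with the structure `Cn1cccc1-c1ccccc1NCC1=NCCN1`, stands highest of the two numbers measured so far in a functional assay with Alpha-1A adrenergic receptor (Homo sapiens) as the target, read by calcium flux; on this read-out higher numbers stand for larger maximal responses and lower numbers for smaller maximal responses: compound 1 reaches 103%. Compound 2, with the structure `Cn1ncnc1-c1ccccc1NCC1=NCCN1`, differs from it only in the ring that hangs from the shared core, and in this assay compound 2 reaches 91%, a step of a number 12 percentage points lower from compound 1 to compound 2 (beyond the scatter).

Compound 3, with the structure `CCn1cccc1-c1ccccc1NCC1=NCCN1`, differs from compound 1 in another way: methyl in place of hydrogen on a saturated chain carbon bound to an aromatic nitrogen. Among the measured compounds shown here, none of the measured steps touches this place; the only step known exchanges a whole ring, while here a single carbon is added to a methyl on a chain carbon bound to an aromatic nitrogen. With nothing to lean on, a step of no more than the usual scatter is expected in this assay, in either direction, that is a number 3 percentage points lower from compound 1 to compound 3 (within the scatter). Compound 3 is therefore expected to reach about 100%, most likely between 82% and 115%.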

Compound 3, largest response reached (reported as maximal response), in percent of the reference or control that the assay uses: 93%
Beside the measured number, compound 3's estimate is 7 percentage points above it, and the stated range covers the measured number.
By their numbers in this assay, from the lowest: compounds 2, 3 and 1 (each within the scatter of the next, the first and the last beyond it).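

Among these compounds, the change from methyl to ethyl, on a saturated chain carbon bound to an aromatic nitrogen, gives a number 10 percentage points lower from compound 1 to compound 3 (within the scatter) in this assay, so this is the first look at this place on the molecule. Adding one carbon here leaves no difference that can be told apart from the ordinary spread of repeated measurements, so the place tolerates at least this small addition without a clear effect on the maximal response. Nothing available here bears on why the result came out this way.

Still open, from the compounds shown here alone, is whether a longer chain such as propyl, or a chain ending in an amine or a carboxylic acid, would also stay within the scatter. Going by these compounds, it is equally open whether the same methyl to ethyl change would behave alike on the ring of compound 2.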